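This account rests on a few compounds, and the source may have more. Where it says the series, first, only, none or still open, it means among the compounds named here.

Three esters built on one shared core have been tested in a functional assay on HeLa cells (Homo sapiens) for inhibition, read by sulforhodamine B assay, with a stated time of 48 h; a lower number here means a stronger inhibitor of growth, a higher number a weaker inhibitor of growth. Compound 1 `O=C(/C=C/c1ccccc1)OCC1COCCOCCOCCOCCOCCO1` gives 48000 nM. Compound 2 `O=C(CCCCCc1ccccc1)OCC1COCCOCCOCCOCCOCCO1` gives 79000 nM, and compound 3 `O=C(CCCCC1CCCCC1)OCC1COCCOCCOCCOCCOCCO1` gives 71000 nM. Compound 3 thus stands in the middle of the three numbers, though with a 1.1-fold lower number from compound 2 to compound 3 (0.05 log units; within the scatter) and a 1.5-fold higher number from compound 1 to compound 3 (0.17 log units; within the scatter) all three lie within the scatter of one another. Compound 4 `CC(C)=CC1C(C(=O)OCC2COCCOCCOCCOCCOCCO2)C1(C)C` carries a new group on the carbonyl carbon: 2,2-dimethyl-3-(2-methylprop-1-en-1-yl)cyclopropyl in place of 4-cyclohexylbutyl on a carbonyl carbon. Among the measured compounds shown here, the steps that bear on this are the earlier exchanges at the same carbonyl carbon, a 1.6-fold higher number from compound 1 to compound 2 (0.22 log units; within the scatter) and a 1.5-fold higher number from compound 1 to compound 3 (0.17 log units; within the scatter), neither of which moved the number beyond the scatter. The change is therefore expected to be small, a 1.2-fold lower number from compound 3 to compound 4 (0.07 log units; within the scatter). Compound 4 is estimated at 60000 nM, most likely between 25000 nM and 150000 nM.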

Compound 4, concentration for 50% growth inhibition: 63000 nM
Beside the measured number, compound 4's estimate is 1.1-fold (0.02 log units) below it; measured number inside the range.
By their numbers in this assay, from the lowest: compounds 1, 4, 3 and 2 (each within the scatter of the next).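

A three-membered ring with a double bond outside it, on the carbonyl carbon, leaves the number in this assay within the scatter of all three earlier compounds (a 1.1-fold lower number from compound 3 to compound 4 (0.05 log units; within the scatter)) (a 1.3-fold lower number from compound 2 to compound 4 (0.10 log units; within the scatter)) (a 1.3-fold higher number from compound 1 to compound 4 (0.12 log units; within the scatter)). This position has therefore now taken a small ring as well as longer chains ending in a six-membered ring, with no step beyond the scatter. No evidence is available to explain this result. All these groups contain only carbon and hydrogen, so a group bearing an amine or a carboxylic acid at this position remains an open test. Going by these compounds, whether changes to the shared core would move the number also remains open.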